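Adding a chloro group to compound 3

The source may hold more compounds than are shown below. What is called first, only, known or untested is meant among the compounds shown, and "the series" means these compounds.

In a functional assay on SK-MEL-28 cells (Homo sapiens) for inhibition, read by colorimetric assay and MTT assay, with a stated time of 72 h (a higher number here means a weaker inhibitor, a lower number a stronger inhibitor), compound 3 `C=CCCCCOc1ncc(-c2ccccc2OC)n1C` gives 13000 nM and stands as the higher of the two actual numbers shown. Compound 1 `C=CCCCCOc1ccccc1-c1cnc(OCCCCC=C)n1C` gives 5000 nM as the lower of that pair, a gap beyond the scatter. Compound 2 `COc1ccccc1-c1cnc(OC)n1C` reads > 100000 nM and that is a limit, not a number.

Compound 4 `C=CCCCCOc1ncc(-c2ccc(Cl)cc2OC)n1C` differs from compound 3 by chloro in place of hydrogen on an aromatic carbon with chloro in place of hydrogen on an aromatic carbon, meta to a methoxy group and para to a large group. Neither measured step touches that carbon, since both change the chain on the oxygen. Adding pent-4-en-1-yl gave an at least 7.6-fold lower number from compound 2 to compound 3 (0.88 log units; beyond the scatter) and removing it gave a 2.6-fold higher number from compound 1 to compound 3 (0.41 log units; beyond the scatter) so among these three compounds more substitution went with a lower number, and none goes against that. On these indirect grounds a modest move toward a lower number is expected in this assay once chloro enters. The expected step is a 1.6-fold lower number from compound 3 to compound 4 (0.21 log units; within the scatter) and it may not clear the scatter. For compound 4 the estimated value is 8000 nM with an expected range of 3000 nM to 20000 nM on this reasoning.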

Compound 4, half-maximal inhibitory concentration: 50000 nM
Compound 4: middle estimate off by 6.3-fold (0.80 log units), on the low side, outside the stated range (above it).
By their numbers in this assay, from the lowest: compound 1; then compound 3; then compound 4. At a limit, above all of these: compound 2.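

In this assay, a change on the aromatic ring, rather than on the chain on the oxygen, gives a result in the opposite direction: chloro in place of hydrogen on the aromatic carbon meta to the methoxy group and para to a large group gives a 3.8-fold higher number from compound 3 to compound 4 (0.59 log units; beyond the scatter). The earlier link between more substitution and a lower number therefore does not carry over to this carbon, and compound 4 goes against it. Only compound 2 reads as a limit, so this step joins two actual numbers: the limit of > 100000 nM in this assay, at which 1 of the 4 values shown sits.

The compounds shown leave open whether this move belongs to chloro alone or would also follow a fluoro, methyl or nitrile group on the same carbon. They also leave open whether chloro here would shift compound 1 in the same direction.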